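Chromene tracheal relaxants: trading the dicyanoethenyl for hydroxy

A few compounds are considered here, and "the series" means these few. Any claim that something is new, unique, unknown or untested is made for them only; others in the source may bear on it.

Measured compounds so far:
- compound 1, `CC1(C)C=C(n2ccccc2=O)c2cc(C(=N)NO)ccc2O1` — 5.51
- compound 2, `CC1(C)C=C(n2ccccc2=O)c2cc(C=C(C#N)C#N)ccc2O1` — 6.3

Going by the values given here, in a functional assay (trachea) with Rattus norvegicus as the target (a higher number here means a more potent compound, by a factor of ten per unit of this negative logarithm, a lower number a less potent compound), compound 2 gives 6.3, the higher of the two numbers measured; its only neighbour is compound 1 with 5.51. Among the compounds with values here, the one step recorded, a number 0.79 log units higher from compound 1 to compound 2 (beyond the scatter), shows that the dicyanoethenyl group on the aromatic carbon carries a modest advantage over the amidoxime. Compound 3, `CC1(C)C=C(n2ccccc2=O)c2cc(O)ccc2O1`, now removes that group altogether: hydroxy in place of 2,2-dicyanoethenyl on an aromatic carbon. Within the data shown here, no measured pair shows what a hydroxy does at this position, so the expectation rests on the single step toward the dicyanoethenyl being reversed. Compound 3 is therefore expected to fall back toward the level of compound 1, a step of a number 0.80 log units lower from compound 2 to compound 3 (beyond the scatter) in this assay. The estimate for compound 3 is 5.5, with a range from 4.9 to 6.1.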

Compound 3, logarithm of the reciprocal of the active concentration, log(1/C): 5.31
For compound 3 the middle estimate is 0.19 log units above the measured one; measured number inside the range.
By their numbers in this assay, from the lowest: compounds 3 and 1 (each within the scatter of the next); then compound 2.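

In this assay, hydroxy in place of 2,2-dicyanoethenyl on this aromatic carbon brings a number 0.99 log units lower from compound 2 to compound 3 (beyond the scatter), whereas exchanging the amidoxime for the single oxygen brings only a number 0.20 log units lower from compound 1 to compound 3 (within the scatter). Among the three groups shown at this position, the 2,2-dicyanoethenyl alone stands apart, while the hydroxy and the larger amidoxime cannot be told apart in this measurement. No supporting measurement is available to explain why the 2,2-dicyanoethenyl differs from the other two groups.

The compounds shown leave open whether the advantage of compound 2 depends on both nitrile groups, on one of them, or on the double bond that carries them. A single nitrile, a carboxylic acid or an amine on the same aromatic carbon would show how far any such group can move the number away from the level of compound 1 and compound 3.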